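An Acetyl Group Added to the Biphenyl Amide

A few compounds are considered here, and "the series" means these few. Any claim that something is new, unique, unknown or untested is made for them only; others in the source may bear on it.

Three amides on a shared core were tested in an ADME assay on WI-38 cells (Homo sapiens) for cytotoxicity, read by MTT assay, with a stated time of 72 h; a lower number here means a stronger inhibitor, a higher number a weaker inhibitor. Compound 1 `O=C(CCc1cccc2c1B(O)OC2)Nc1ccc(F)cc1` gives 12000 nM in this assay. Compound 2 `O=C(CCc1cccc2c1B(O)OC2)Nc1ccc2ccccc2c1` reaches only a limit of this assay, > 100000 nM; one of the three values is such a limit (the limit of > 100000 nM in this assay, at which 1 of the 3 values shown sits). Compound 3 `O=C(CCc1cccc2c1B(O)OC2)Nc1cccc(-c2ccccc2)c1` gives 12000 nM in this assay, level with compound 1 within the scatter. Compound 4 `CC(=O)c1cccc(-c2cccc(NC(=O)CCc3cccc4c3B(O)OC4)c2)c1` has not yet been measured; it differs from compound 3 by acetyl in place of hydrogen on an aromatic carbon. Going by the values given here, with no measured step of this kind to guide it, the account expects the step of a 1.3-fold higher number from compound 3 to compound 4 (0.10 log units; within the scatter) to stay within the scatter, leaning if anything toward a weaker inhibitor. The estimated value for compound 4 in this assay is 15000 nM, ranging from 6000 nM to 50000 nM.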

Compound 4, half-maximal inhibitory concentration: 2200 nM
The estimate for compound 4 lay 6.8-fold (0.83 log units) above the measured number, outside the stated range (below it).
By their numbers in this assay, from the lowest: compound 4; then compounds 1 and 3 (each within the scatter of the next). At a limit, above all of these: compound 2.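

The change from phenyl to 3-acetylphenyl gives a 5.5-fold lower number from compound 3 to compound 4 (0.74 log units; beyond the scatter) in this assay, the first single-place comparison among these compounds. It shows that the number responds to a substituent on this outer ring, with acetyl taking it in the direction of stronger inhibition. Nothing measured here gives a reason for this step.

From the compounds shown here alone, it remains open whether this step belongs to acetyl itself or would also appear with another group at this place, such as an amine, a carboxylic acid or a nitrile. Going by these compounds, whether acetyl elsewhere on this ring would give a similar step also remains open.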